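A Trifluoromethyl Swap on the Aryl Amide

The source may hold more compounds than are shown below. What is called first, only, known or untested is meant among the compounds shown, and "the series" means these compounds.

In a functional assay on A549 cells (Homo sapiens) for inhibition, read by CCK-8 assay, with a stated time of 72 h, tested at 10 uM (a lower number here means less inhibition of growth, a higher number more inhibition of growth at the concentration tested), compound 3 (`Cc1ccc(NC(=O)C2(C(=O)Nc3ccc(Nc4ncc5cc(C(=O)N(C)C)n(C6CCCC6)c5n4)cc3)CC2)cc1`) reaches 90.6% and lies within the scatter of compound 1 (`CN(C)C(=O)c1cc2cnc(Nc3ccc(NC(=O)C4(C(=O)Nc5cccc(F)c5)CC4)cc3)nc2n1C1CCCC1`) at 91.8% while compound 2 (`COc1ccc(NC(=O)C2(C(=O)Nc3ccc(Nc4ncc5cc(C(=O)N(C)C)n(C6CCCC6)c5n4)cc3)CC2)cc1`) trails at 78.5% in the same test. Compound 4 (`CN(C)C(=O)c1cc2cnc(Nc3ccc(NC(=O)C4(C(=O)Nc5cccc(C(F)(F)F)c5)CC4)cc3)nc2n1C1CCCC1`) carries 3-(trifluoromethyl)phenyl in place of 4-methylphenyl on an amide-type nitrogen. Going by the values given here, three measured steps bear on this change. Exchanging the aryl group on that nitrogen gave little in one case (a number 1.2 percentage points lower from compound 1 to compound 3 (within the scatter)) and only the 4-methoxyphenyl of compound 2 departs (a number 13.3 percentage points lower from compound 1 to compound 2 (beyond the scatter); a number 12.1 percentage points higher from compound 2 to compound 3 (beyond the scatter)). Compound 4 has no methoxy, so no shift beyond the scatter is expected. The expected change is small (a number 2.6 percentage points lower from compound 3 to compound 4 (within the scatter)). Compound 4 is estimated at 88% (range 74% to 97%) in this assay by this reckoning.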

Compound 4, percent growth inhibition at one concentration: 89.2%
Beside the measured number, compound 4's estimate is 1.2 percentage points below it, and the stated range covers the measured number.
By their numbers in this assay, from the lowest: compound 2; then compounds 4, 3 and 1 (each within the scatter of the next).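

At the amide-type nitrogen, 3-(trifluoromethyl)phenyl leaves the result in this assay unmoved within the scatter, both against 4-methylphenyl (a number 1.4 percentage points lower from compound 3 to compound 4 (within the scatter)) and with trifluoromethyl in place of fluoro (a number 2.6 percentage points lower from compound 1 to compound 4 (within the scatter)). Against 4-methoxyphenyl the step lies beyond the scatter (a number 10.7 percentage points higher from compound 2 to compound 4 (beyond the scatter)), so among these four compounds only compound 2 stands apart. Nothing measured here explains this difference.

The compounds leave open whether an aryl ring bearing an amine or a carboxylic acid would keep this inhibition. On these data alone, whether a cyclohexyl group could replace the aryl ring on that nitrogen also stays open.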